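Two Aryl Imides Measured, a Dimethylphenyl Analogue Expected

This account rests on a few compounds, and the source may have more. Where it says the series, first, only, none or still open, it means among the compounds named here.

Measured compounds:
compound 1 `COc1ccc(N2C(=O)[C@H]3[C@H](ON4[C@@H]3C(=O)N(C)[C@@]43C[C@H](C)CC[C@H]3C(C)C)C2=O)cc1` gives 67.7%
compound 2 `Cc1cccc(N2C(=O)[C@H]3[C@H](ON4[C@@H]3C(=O)N(C)[C@@]43C[C@H](C)CC[C@H]3C(C)C)C2=O)c1` gives 65.8%

In a functional assay, read by spectrophotometry, with a stated time of 2 h, tested at 3 mg/mL (on this read-out higher numbers stand for a stronger effect at the one concentration tested and lower numbers for a weaker effect), compound 2 gives 65.8%, and compound 1 gives 67.7%, so the two stand within the scatter of each other. Compound 3 `Cc1ccc(N2C(=O)[C@H]3[C@H](ON4[C@@H]3C(=O)N(C)[C@@]43C[C@H](C)CC[C@H]3C(C)C)C2=O)c(C)c1` is not yet measured; it differs from compound 2 by 2,4-dimethylphenyl in place of 3-methylphenyl on an amide-type nitrogen in a ring. Among the measured compounds shown here, the only step that bears on it, a change of the group on the same ring nitrogen, is a number 1.9 percentage points lower from compound 1 to compound 2 (within the scatter). For compound 3 a step of a number 0.8 percentage points lower from compound 2 to compound 3 (within the scatter) is therefore expected, with no shift beyond the scatter, and compound 3 is estimated at 65% within 50% to 78%.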

Compound 3, a percentage reported as activity, at one concentration (the size of the read-out at that concentration, not a potency): 71.3%
The estimate for compound 3 lay 6.3 percentage points below the measured number; low and high end bracket the measured number.
By their numbers in this assay, from the lowest: compounds 2, 1 and 3 (each within the scatter of the next).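

In this assay the 2,4-dimethylphenyl group gives a number 5.5 percentage points higher from compound 2 to compound 3 (within the scatter) when it replaces 3-methylphenyl, and a number 3.6 percentage points higher from compound 1 to compound 3 (within the scatter) when it replaces 4-methoxyphenyl on the same ring nitrogen. Three different substituted phenyl groups have now stood at this nitrogen with no shift beyond the scatter, so adding a methyl group to the ring, or exchanging methoxy for methyl, does not clearly move the number here. No measured evidence accounts for these small steps. Still open, from the compounds shown here alone, is whether a cyclohexyl ring, or a phenyl ring carrying an amine or a carboxylic acid, would keep the number at this level.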